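The compounds below may be only part of what the source reports. "The series", "measured", "known", "first", "only" and "open" are said of these compounds alone.

Compound 1 `CNc1nc(-n2cc(-c3ccccn3)nn2)nc2c1ncn2[C@@H]1O[C@H](CO)[C@@H](O)[C@H]1O` gives 1970 nM in an assay on CHO cells for displacement of a labelled ligand from adenosine receptor A1 (Homo sapiens); on this read-out lower numbers stand for stronger inhibition and higher numbers for weaker inhibition. Among the three compounds measured, compound 1 has the highest number: compound 2 `CCNC(=O)[C@H]1O[C@@H](n2cnc3c(NC)nc(-n4cc(CC5CCCC5)nn4)nc32)[C@H](O)[C@@H]1O` gives 1250 nM in this assay, which lies within the scatter of compound 1, while compound 3 `COc1ccc(Cl)c(CNc2nc(-n3cc(CC4CCCC4)nn3)nc3c2ncn3[C@@H]2O[C@H](CO)[C@@H](O)[C@H]2O)c1` gives 830 nM, a gap beyond the scatter. Compound 4 `CNc1nc(-n2cc(Cc3ccccc3)nn2)nc2c1ncn2[C@@H]1O[C@H](CO)[C@@H](O)[C@H]1O` differs from compound 1 by a benzyl in place of pyridin-2-yl on an aromatic carbon. For the measured compounds named here, no measured pair shows this single change; compounds 2 and 3 carry a cyclopentylmethyl group instead, but they differ elsewhere as well. Compound 4 is expected to give a somewhat lower number, a step of a 2.0-fold lower number from compound 1 to compound 4 (0.29 log units; within the scatter), close to the scatter. Compound 4 is estimated at 1000 nM, with a range of 400 nM to 2500 nM.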

Compound 4, inhibition constant: 589 nM
Beside the measured number, compound 4's estimate is 1.7-fold (0.23 log units) above it, within the range that was stated.
By their numbers in this assay, from the lowest: compounds 4, 3, 2 and 1 (each within the scatter of the next, the first and the last beyond it).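

Benzyl in place of pyridin-2-yl gives a 3.3-fold lower number from compound 1 to compound 4 (0.52 log units; beyond the scatter) in this assay and is the first change confined to one place that can be read here. For the compounds shown here, it shows that the number responds to the group on this aromatic carbon of the five-membered ring, a step that the earlier compounds, which differ in more than one place, could not isolate. Nothing measured here accounts for the step. Going by these compounds, whether it follows from the lost ring nitrogen or from the added carbon stays open, and a phenyl group at this position would separate the two.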